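Moving the Nitro Group on Compound 3

The source may report more compounds than this note shows. Statements on the series, on what has been measured and on what is new or still open speak of the compounds shown alone.

In an ADME assay on MT4 cells (Homo sapiens) for cytotoxicity, read by MTT assay (a higher number here means that more compound is tolerated, a lower number that less compound is tolerated), compound 3 `Cc1ccc(N(C(=O)c2ccccc2[N+](=O)[O-])C(=S)OCCN2C(=O)c3ccccc3C2=O)cc1` gives 100000 nM, the higher of the two exact numbers, and compound 2 `O=C1c2ccccc2C(=O)N1CCOC(=S)N(C(=O)c1ccccc1[N+](=O)[O-])c1ccc(Cl)cc1` gives 21000 nM. Compound 1 `CCCCCOc1ccc(C(=O)N(C(=S)OCCN2C(=O)c3ccccc3C2=O)c2ccc(F)cc2)cc1` reads > 100000 nM, which is a limit of the assay and not a number.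

The next compound, compound 4 `Cc1ccc(N(C(=O)c2ccc([N+](=O)[O-])cc2)C(=S)OCCN2C(=O)c3ccccc3C2=O)cc1`, keeps the atoms of compound 3 but joins them differently: 4-nitrophenyl in place of 2-nitrophenyl on a carbonyl carbon. It carries 4-nitrophenyl in place of 2-nitrophenyl on a carbonyl carbon. Within the data shown here, no measured step tests this exchange directly. Among the measured compounds shown here, the only measured step is a 4.8-fold higher number from compound 2 to compound 3 (0.68 log units; beyond the scatter), with methyl in place of chloro on an aromatic carbon, and it leaves the 2-nitrophenyl untouched. The expectation therefore rests on compound 3 at 100000 nM, with that modest step as a rough guide to size. No clear direction can be drawn from it, and this assay may again return only a limit.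

The estimated change is a 1.4-fold lower number from compound 3 to compound 4 (0.15 log units; within the scatter), so no shift beyond the scatter is expected. For compound 4 the expected value is 70000 nM, with an estimated range of 22000 nM to 160000 nM.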

Compound 4, half-maximal cytotoxic concentration: 58000 nM
The estimate for compound 4 lay 1.2-fold (0.08 log units) above the measured number, within the range that was stated.
By their numbers in this assay, from the lowest: compound 2; then compounds 4 and 3 (each within the scatter of the next).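

In this assay, the exchange of 2-nitrophenyl for 4-nitrophenyl on the carbonyl carbon gives a 1.7-fold lower number from compound 3 to compound 4 (0.24 log units; within the scatter), so this pair shows that the read-out does not separate the two nitrophenyl groups when the rest of the molecule is held fixed. The earlier step with methyl in place of chloro, a 4.8-fold higher number from compound 2 to compound 3 (0.68 log units; beyond the scatter), is still the only step shown that lies beyond the scatter, so among these compounds a clear change comes from that exchange and not from this one. Compound 1 remains the only compound that reads as a limit and not as a number: the limit of > 100000 nM in this assay, at which 1 of the 4 values shown sits.

Going by these compounds, it remains open whether the two nitrophenyl groups would also read alike with chloro in place of methyl. An amine or a carboxylic acid in place of the nitro group at this position also remains untested among the compounds shown here.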